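Swapping methoxy for hydroxy on a pyrazole growth inhibitor

This account rests on a few compounds, and the source may have more. Where it says the series, first, only, none or still open, it means among the compounds named here.

Of the compounds shown here, three sharing one core have been tested so far. In a functional assay on HCT-116 cells (Homo sapiens) for inhibition, read by sulforhodamine B assay, with a stated time of 48 h (a higher number here means a weaker inhibitor of growth, a lower number a stronger inhibitor of growth), compound 1 `COc1cc(C)cc(-c2c(-c3ccnc(-c4ccc(C(C)=O)cc4)c3)cnn2CC#N)c1` gives 5400 nM. Compound 2 `Cc1cc(O)cc(-c2nn(CC#N)cc2-c2ccnc(-c3ccc(Oc4ccccc4)cc3)c2)c1` gives 2900 nM in this assay. Compound 3 `COc1cc(C)cc(-c2nn(CC#N)cc2-c2ccnc(-c3ccc(N(C)C)cc3)c2)c1` gives 1640 nM in this assay, the lowest of the three numbers. The gap between compound 3 and compound 2 is within the usual scatter of this assay, so the two cannot be ranked against each other; the gap between compound 3 and compound 1 is beyond the scatter, so compound 3 is clearly the stronger inhibitor of growth of that pair.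

The next compound, compound 4 `Cc1cc(O)cc(-c2nn(CC#N)cc2-c2ccnc(-c3ccc(N(C)C)cc3)c2)c1`, keeps everything of compound 3 except one point: hydrogen in place of methyl on an oxygen on an aromatic ring. Compound 2 already carries this hydroxy group, but with a different group on the far aryl ring, so no direct comparison of methoxy against hydroxy exists among the measured compounds. Among the measured compounds shown here, with no such pair to lean on, the change is expected to move the number little, if at all, beyond the scatter, and the step from compound 3 to compound 4 is estimated as a 1.0-fold lower number from compound 3 to compound 4 (0.01 log units; within the scatter). Compound 4 is therefore expected to give about 1600 nM in this assay, plausibly between 600 nM and 4500 nM.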

Compound 4, concentration for total growth inhibition: 10400 nM
Compound 4: middle estimate off by 6.5-fold (0.81 log units), on the low side, outside the stated range (above it).
By their numbers in this assay, from the lowest: compounds 3, 2, 1 and 4 (each within the scatter of the next, the first and the last beyond it).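

In this assay the methoxy group on the 3-methoxy-5-methylphenyl ring cannot be swapped for hydroxy without a cost: with everything else held fixed, hydrogen in place of methyl on that oxygen gives a 6.3-fold higher number from compound 3 to compound 4 (0.80 log units; beyond the scatter) and so weakens growth inhibition beyond the scatter. Among the compounds shown here, compound 4 also gives the first single-change comparison at the far aryl ring, where dimethylamino in place of phenoxy gives a 3.6-fold higher number from compound 2 to compound 4 (0.55 log units; beyond the scatter) and shows that, with hydroxy present, the phenoxy compound is the stronger inhibitor of the pair. No measurement here explains either step.

For the compounds shown here, whether the methoxy-to-hydroxy step keeps this size when phenoxy or acetyl-bearing far rings are present remains open, since each of those is seen with only one of the two groups on the oxygen. Also open, from the compounds shown here alone, is how this position responds to other groups, such as an ethoxy group, a longer chain on the oxygen, or an amine in place of the oxygen.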